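Compound 4: difluorophenyl carbonyl in place of nitrophenyl carbonyl

The source may hold more compounds than are shown below. What is called first, only, known or untested is meant among the compounds shown, and "the series" means these compounds.

Values read in a functional assay on A549 cells (Homo sapiens) for inhibition, read by MTT assay, with a stated time of 72 h; on this read-out lower numbers stand for stronger inhibition and higher numbers for weaker inhibition:
compound 1 `CN(C(=O)NC(=O)c1cccc(C(F)(F)F)c1)c1nc(C(F)(F)F)c(C(=O)N/N=C/c2ccccc2C(F)(F)F)s1`: 12.1 ug/mL
compound 2 `CN(C(=O)NC(=O)c1cccc([N+](=O)[O-])c1)c1nc(C(F)(F)F)c(C(=O)N/N=C/c2ccccc2C(F)(F)F)s1`: 5.45 ug/mL
compound 3 `CNc1nc(C)c(C(=O)N/N=C/c2ccccc2C(F)(F)F)s1`: > 100 ug/mL, a limit of the assay and not a number.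

For the measured compounds named here, compound 2 stands lowest of the two numbers read in this assay; compound 1 is the nearest, and the single measured step is a 2.2-fold lower number from compound 1 to compound 2 (0.35 log units; beyond the scatter). The value of compound 3 is the limit of > 100 ug/mL in this assay, at which 1 of the 3 values shown sits.

Compound 4 `CN(C(=O)NC(=O)c1c(F)cccc1F)c1nc(C(F)(F)F)c(C(=O)N/N=C/c2ccccc2C(F)(F)F)s1` changes the same carbonyl position as that step: 2,6-difluorophenyl in place of 3-nitrophenyl on a carbonyl carbon. The step from compound 1 to compound 2 is the only one that bears on this position, and it was modest. The group entering in compound 4 is neither the nitro that gave the lower number nor the trifluoromethyl of compound 1, so the expected move is a modest step back toward the number of compound 1, about a 1.7-fold higher number from compound 2 to compound 4 (0.22 log units; within the scatter), with the outcome possibly within the scatter. Compound 4 is therefore estimated at 9 ug/mL in this assay, in the range 3 ug/mL to 30 ug/mL.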

Compound 4, half-maximal inhibitory concentration: 17.9 ug/mL
Compound 4: the middle estimate sits 2.0-fold (0.30 log units) below what was measured; the range from low to high includes it.
By their numbers in this assay, from the lowest: compound 2; then compounds 1 and 4 (each within the scatter of the next). At a limit, above all of these: compound 3.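

In this assay, the 2,6-difluorophenyl group on a carbonyl carbon whose other neighbour is an amide-type nitrogen gives a 3.3-fold higher number from compound 2 to compound 4 (0.52 log units; beyond the scatter), so the lower number at this position is not reproduced by this second change of aryl group. Set against the 3-(trifluoromethyl)phenyl group, the same entering group gives a 1.5-fold higher number from compound 1 to compound 4 (0.17 log units; within the scatter), which leaves 3-nitrophenyl as the only one of the three groups standing apart at this position. No measurement shown offers a cause for these steps.

Open, on these data alone, is whether the lower number of compound 2 belongs to the nitro group itself, which an amine or a nitrile in its place would test. For the compounds shown here, compound 3, whose > 100 ug/mL is a limit and not a number, differs from the others in more than one place, so no step to it can be read.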